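The compounds below may be only part of what the source reports. "The series", "measured", "known", "first", "only" and "open" are said of these compounds alone.

Working notes on the series. Of the compounds shown here, two have been measured in a functional assay on MKN-74 cells (Homo sapiens) for antiproliferative activity, with a stated time of 24 h; on this read-out lower numbers stand for stronger inhibition and higher numbers for weaker inhibition. Compound 1 `COc1ccccc1NC(=S)N1CCc2c(sc(NC(=O)c3ccccc3Cl)c2C(N)=O)C1` carries a 2-methoxyphenyl thiourea on the shared core; in this assay compound 1 gives 35200 nM. Compound 2 `NC(=O)c1c(NC(=O)c2ccccc2Cl)sc2c1CCN(C(=S)Nc1cc(C(F)(F)F)cc(C(F)(F)F)c1)C2` carries instead a 3,5-bis(trifluoromethyl)phenyl thiourea; in this assay compound 2 gives 15000 nM. Of the two numbers, compound 2 stands lowest, and the gap to compound 1 lies beyond the scatter of this read-out, so compound 2 is the stronger inhibitor of the pair as measured.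

Compound 3 `Cc1ccc(C(=O)Nc2sc3c(c2C(N)=O)CCN(C(=S)Nc2cc(C(F)(F)F)cc(C(F)(F)F)c2)C3)cc1` keeps the thiourea part of compound 2 and changes only the acyl group: 4-methylphenyl in place of 2-chlorophenyl on a carbonyl carbon. Among the compounds with values here, no measured pair in this assay isolates this exchange, so the direction of the step cannot be read from the data. Within the data shown here, the one measured step concerns a different place on the core and says nothing about the acyl group. The step from compound 2 to compound 3 is therefore expected to be small, a 1.2-fold higher number from compound 2 to compound 3 (0.08 log units; within the scatter), not clearly beyond the scatter in either direction. For compound 3 the expected value in this assay is 18000 nM, with a range of 6000 nM to 55000 nM.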

Compound 3, half-maximal inhibitory concentration: 14900 nM
Beside the measured number, compound 3's estimate is 1.2-fold (0.08 log units) above it, and the stated range covers the measured number.
By their numbers in this assay, from the lowest: compounds 3 and 2 (each within the scatter of the next); then compound 1.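

Within the data shown here, this is the first measured step at the acyl position of the series: in this assay, with the 3,5-bis(trifluoromethyl)phenyl thiourea held constant, 4-methylphenyl in place of 2-chlorophenyl on a carbonyl carbon gives a 1.0-fold lower number from compound 2 to compound 3 (0.00 log units; within the scatter) and so leaves the number within the scatter. The two aryl groups, which share a six-membered aromatic ring of carbon and differ in their substituent and its ring position, therefore cannot be told apart on this read-out in this thiourea setting. No supporting data bear on why the exchange leaves the read-out within the scatter.

This single pair leaves open whether the same exchange would also stay within the scatter with the 2-methoxyphenyl thiourea of compound 1, and it does not separate the change of substituent from the change of its ring position. It also leaves open how the read-out would respond to groups of a different kind on that carbonyl carbon, such as a dimethylamino group, a carboxylic acid or a longer alkyl chain in place of the aryl ring.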